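A few compounds are considered here, and "the series" means these few. Any claim that something is new, unique, unknown or untested is made for them only; others in the source may bear on it.

In a functional assay on HCT-15 cells (Homo sapiens) for cytotoxicity, read by ELISA, with a stated time of 4 days (a lower number here means a stronger inhibitor, a higher number a weaker inhibitor), compound 1 (`Cc1ccsc1-c1cc(-c2ccoc2)cc(-c2ccc(Cl)cc2)n1`) gives 2990 nM and compound 2 (`Clc1ccc(-c2cc(-c3ccoc3)cc(-c3ccccc3Cl)n2)s1`) gives 1100 nM. Compound 2 thus has the lower of the two numbers, and the gap between them lies beyond the scatter. Compound 3 (`Clc1ccc(-c2cc(-c3ccoc3)cc(-c3ccc(Cl)s3)n2)cc1`) has yet to be measured. It carries 4-chlorophenyl in place of the 2-chlorophenyl of compound 2, on an aromatic carbon next to the ring nitrogen (4-chlorophenyl in place of 2-chlorophenyl on an aromatic carbon). Among the measured compounds shown here, no measured pair shows this exchange alone, so the guide is thin: compound 1 also carries 4-chlorophenyl and gives 2990 nM. The expected change in this assay is a small rise in the number, toward weaker inhibition, estimated as a 1.5-fold higher number from compound 2 to compound 3 (0.19 log units; within the scatter) and expected to stay within the scatter. For compound 3 the estimate is 1700 nM, with an expected range of 600 nM to 5000 nM.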

Compound 3, half-maximal inhibitory concentration: 640 nM
Compound 3: the middle estimate sits 2.7-fold (0.42 log units) above what was measured, and the stated range covers the measured number.
By their numbers in this assay, from the lowest: compounds 3 and 2 (each within the scatter of the next); then compound 1.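

In this assay, the exchange of 2-chlorophenyl for 4-chlorophenyl on the aromatic carbon next to the ring nitrogen can now be read alone: a 1.7-fold lower number from compound 2 to compound 3 (0.24 log units; within the scatter), so the place of the chlorine on this phenyl ring makes no difference beyond the scatter. The exchange of 3-methylthiophen-2-yl for 5-chlorothiophen-2-yl, with 4-chlorophenyl held fixed, gives a 4.7-fold lower number from compound 1 to compound 3 (0.67 log units; beyond the scatter), a change that does lie beyond the scatter. No measurement shown accounts for either step.

The compounds shown leave open whether a group of another kind on that carbon, such as a phenyl ring bearing an amine or a carboxylic acid, would shift the number beyond the scatter. From the compounds shown here alone, all three carry furan-3-yl, so what that group contributes also remains open.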